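A few compounds are considered here, and "the series" means these few. Any claim that something is new, unique, unknown or untested is made for them only; others in the source may bear on it.

Measured so far in an in vitro ADME assay on microsomes from liver (Homo sapiens) for metabolic stability; a lower number here means slower removal, a higher number faster removal of the compound:
- compound 1 `Fc1ccccc1Cc1nc(-c2nc(Cc3ccccc3)n[nH]2)n2ccccc12`: "not determined" (no result reported)
- compound 2 `Cc1n[nH]c(-c2nc(Cc3ccccc3F)c3ccccn23)n1`: 124 mL.min-1.g-1
- compound 3 `Fc1ccccc1Cc1nc(-c2nc(C(F)(F)C(F)(F)F)n[nH]2)n2ccccc12`: 92 mL.min-1.g-1

Compound 3 stands level with compound 2 within the scatter, and compound 1 offers no number for comparison.

Next is compound 4 `CS(=O)(=O)c1n[nH]c(-c2nc(Cc3ccccc3F)c3ccccn23)n1`, with methylsulfonyl in place of 1,1,2,2,2-pentafluoroethyl on an aromatic carbon. For the measured compounds named here, the only measured step at this place is a 1.3-fold lower number from compound 2 to compound 3 (0.13 log units; within the scatter), where 1,1,2,2,2-pentafluoroethyl replaced methyl. Going by the values given here, no measured compound carries methylsulfonyl, so this small step is the only guide. In this assay, the expectation is therefore no shift beyond the scatter. The estimated change is a 1.2-fold lower number from compound 3 to compound 4 (0.09 log units; within the scatter). For compound 4 the expected value is 75 mL.min-1.g-1, with an estimated range of 30 mL.min-1.g-1 to 150 mL.min-1.g-1.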

Compound 4, intrinsic clearance in microsomes in the Homo sapiens assay: 11 mL.min-1.g-1
The estimate for compound 4 lay 6.8-fold (0.83 log units) above the measured number; measured number below the stated range.
By their numbers in the Homo sapiens assay, from the lowest: compound 4; then compounds 3 and 2 (each within the scatter of the next).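

For the compounds shown here, this position is not indifferent in the Homo sapiens assay: the replacement of the earlier groups by methylsulfonyl gives an 8.4-fold lower number from compound 3 to compound 4 (0.92 log units; beyond the scatter) and an 11-fold lower number from compound 2 to compound 4 (1.05 log units; beyond the scatter), whereas the only earlier change here stayed within the scatter. The lower clearance of compound 4 may be due to its lower lipophilicity in a physicochemical assay for lipophilicity, measured as octanol-water partition, at pH 7.4; a higher number here means a more lipophilic compound, a lower number a more polar compound: the measured distribution coefficient of compound 3, 4.2, and of compound 4, 1.2, a number 3.00 log units lower (beyond the scatter) In the physicochemical assay compound 3 gives 4.2 and compound 4 gives 1.2.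

From the compounds shown here alone, whether the lower clearance goes with methylsulfonyl itself or with the lower distribution coefficient stays open. The compounds shown offer no other group at this place, such as a nitrile or an amide, to separate the two.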